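The source may hold more compounds than are shown below. What is called first, only, known or untested is meant among the compounds shown, and "the series" means these compounds.

The series shares one core; compound 1 `Cn1cnnc1SCC(=O)N/N=c1/scc(-c2ccc(C#N)cc2)n1-c1ccccc1` carries a 4-methyl-4H-1,2,4-triazol-3-yl on the sulfur, and in a functional assay on C6 cells (Rattus norvegicus) for cytotoxicity, read by MTT assay, with a stated time of 24 h, tested at 50 ug/mL (a higher number here means a weaker effect of the compound at the concentration tested, a lower number a stronger effect), compound 1 gives 58.8%. Compound 2 `Cn1nnnc1SCC(=O)N/N=c1/scc(-c2ccc(C#N)cc2)n1-c1ccccc1` has 1-methyl-1H-tetrazol-5-yl there instead, and in this assay compound 2 gives 35.6%, the lowest of the three numbers and so the strongest effect of the set. Compound 3 `N#Cc1ccc(-c2cs/c(=N/NC(=O)CSc3nnnn3-c3ccccc3)n2-c2ccccc2)cc1` carries 1-phenyl-1H-tetrazol-5-yl, and in this assay compound 3 gives 61.1%. Within the data shown here, the steps so far read a number 23.2 percentage points lower from compound 1 to compound 2 (beyond the scatter), a number 2.3 percentage points higher from compound 1 to compound 3 (within the scatter) and a number 25.5 percentage points higher from compound 2 to compound 3 (beyond the scatter). Compound 4 `Cn1nnnc1SCC(=O)N/N=c1/scc(-c2ccccc2)n1-c1ccccc1` keeps the 1-methyl-1H-tetrazol-5-yl of compound 2; the change is hydrogen in place of cyano on an aromatic carbon. Among the measured compounds shown here, none of the measured steps touches that side of the molecule: all three alter the group on the sulfur. For the measured compounds named here, there is thus no direct precedent for this change in this assay, and no step beyond the scatter can be argued from the data. Relative to compound 2, compound 4 is therefore expected to show a number 6.4 percentage points higher from compound 2 to compound 4 (within the scatter), a step within the scatter. The estimate for compound 4 in this assay is 42%, with a range from 22% to 66%.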

Compound 4, a percentage reported as activity, at one concentration (the size of the read-out at that concentration, not a potency): 56.2%
Compound 4: middle estimate off by 14.2 percentage points, on the low side; the range from low to high includes it.
By their numbers in this assay, from the lowest: compound 2; then compounds 4, 1 and 3 (each within the scatter of the next).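

Among these compounds, the first change on this side of the molecule matters: with the 1-methyl-1H-tetrazol-5-yl held on the sulfur, this assay reads a number 20.6 percentage points higher from compound 2 to compound 4 (beyond the scatter), a weaker effect on going from 4-cyanophenyl to phenyl. The low number of compound 2 therefore depends on the cyano as well as on the group on the sulfur, since a number 23.2 percentage points lower from compound 1 to compound 2 (beyond the scatter) shows a step beyond the scatter at that other place too. Nothing measured here explains the cyano step.

The compounds shown leave open whether removing the cyano has a similar effect with the 4-methyl-4H-1,2,4-triazol-3-yl of compound 1 or the 1-phenyl-1H-tetrazol-5-yl of compound 3 on the sulfur. They also leave open how an amine, a carboxylic acid or a methoxy group at the cyano position would read.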